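A Side-Chain Exchange on the Shared Core

The compounds below may be only part of what the source reports. "The series", "measured", "known", "first", "only" and "open" are said of these compounds alone.

In a functional assay on DU-145 cells (Homo sapiens) for antiproliferative activity, read by sulforhodamine B assay, with a stated time of 3 days (on this read-out higher numbers stand for weaker inhibition of growth and lower numbers for stronger inhibition of growth), compound 1 `O=C(Nc1cccc(Nc2ncc(F)c(Nc3ccc(F)cc3)n2)c1)c1ccncc1` gives 4330 nM and compound 2 `CN(C)CC(=O)Nc1cccc(Nc2ncc(F)c(Nc3ccc(F)cc3)n2)c1` gives 1210 nM, the lower of the two numbers. Compound 3 `O=C(NCCO)c1cccc(Nc2ncc(F)c(Nc3ccc(F)cc3)n2)c1` keeps the shared core, but (2-hydroxyethyl)carbamoyl takes the place of (((dimethylamino)methyl)carbonyl)amino on an aromatic carbon: (2-hydroxyethyl)carbamoyl in place of (((dimethylamino)methyl)carbonyl)amino on an aromatic carbon. For the measured compounds named here, only one measured step bears on this change, a 3.6-fold lower number from compound 1 to compound 2 (0.55 log units; beyond the scatter), and it is modest. Going by the values given here, that step alters only the group on a carbonyl carbon, and no measured compound carries the entering group, so the guidance is indirect. Among the compounds with values here, a change of similar size is therefore expected in this assay, most likely toward a higher number, given that compound 2 at 1210 nM is the lowest value so far. The expected change is a 2.1-fold higher number from compound 2 to compound 3 (0.32 log units; beyond the scatter). Compound 3 is estimated at 2500 nM, with an expected range of 600 nM to 10000 nM.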

Compound 3, concentration for 50% growth inhibition: 13400 nM
Compound 3: the middle estimate sits 5.4-fold (0.73 log units) below what was measured; the whole stated range lies below it.
By their numbers in this assay, from the lowest: compound 2; then compound 1; then compound 3.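

In this assay the exchange on this aromatic carbon, meta to a large group, produces an 11-fold higher number from compound 2 to compound 3 (1.04 log units; beyond the scatter), a far larger move than the earlier change on the carbonyl carbon. The same entering group also compares poorly with the other leaving side chain, with a 3.1-fold higher number from compound 1 to compound 3 (0.49 log units; beyond the scatter), so (2-hydroxyethyl)carbamoyl gives the highest number of the three compounds, whichever of the two groups it replaces. Nothing available explains this difference.

The compounds shown leave open whether the rise follows the carbamoyl link to the ring or the 2-hydroxyethyl end, as both differ together in compound 3. A (2-(dimethylamino)ethyl)carbamoyl group on the same carbon would bear on that question, as would a carboxylic acid there.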